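Replacing fluoro with cyano on the shared core of compound 1

This account rests on a few compounds, and the source may have more. Where it says the series, first, only, none or still open, it means among the compounds named here.

Measured compounds:
compound 1, `CC#C[C@@H](Cc1nnn[nH]1)c1ccc(OCc2ccc3sc(F)c(-c4ccccc4C)c3c2)cc1`, 14 nM in a functional assay on cells for agonist activity at Free fatty acid receptor 1 (Rattus norvegicus), read by FLIPR and calcium flux; on this read-out higher numbers stand for an effect only at larger amounts of compound and lower numbers for an effect already at smaller amounts
compound 2, `CC#C[C@@H](Cc1nnn[nH]1)c1ccc(OCc2ccc3sc(F)c(-c4ccc(OCCOC)cc4C)c3c2)cc1`, 24 nM in this assay

Compound 1 stands alongside compound 2 on the numbers shown: the step of a 1.7-fold higher number from compound 1 to compound 2 (0.23 log units; within the scatter) stays within the scatter, so the two values do not separate. Compound 3, `CC#C[C@@H](Cc1nnn[nH]1)c1ccc(OCc2ccc3sc(C#N)c(-c4ccccc4C)c3c2)cc1`, is not yet measured. It differs from compound 1 by cyano in place of fluoro on an aromatic carbon. For the measured compounds named here, no measured step touches this position. Going by the values given here, the only measured step, a 1.7-fold higher number from compound 1 to compound 2 (0.23 log units; within the scatter), concerns a different group elsewhere on the shared core and itself lies within the scatter, so it gives no direction for the change toward compound 3. The expectation therefore rests on compound 1 alone, and no step beyond the scatter in this assay is expected from compound 1 to compound 3, the estimated step being a 1.4-fold higher number from compound 1 to compound 3 (0.15 log units; within the scatter). For compound 3 the estimate in this assay is 20 nM, with a range from 5 nM to 80 nM.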

Compound 3, half-maximal effective concentration: 19 nM
For compound 3 the middle estimate is 1.1-fold (0.02 log units) above the measured one; measured number inside the range.
By their numbers in this assay, from the lowest: compounds 1, 3 and 2 (each within the scatter of the next).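

For the compounds shown here, at this position, on the aromatic carbon next to the ring sulfur, the first measured change in this assay is cyano in place of fluoro, and it gives a 1.4-fold higher number from compound 1 to compound 3 (0.13 log units; within the scatter) as its step. The position can therefore carry either group without the values separating on this read-out, which the step to compound 2, made elsewhere on the shared core, could not show. Nothing shown accounts for this result or says what the two groups do here.

The compounds shown leave open whether an amine, a carboxylic acid or a longer chain such as 2-methoxyethoxy at this same position would also stay within the scatter of compound 1. They also leave open whether cyano at this position and 2-methoxyethoxy on the 2-methylphenyl group would behave the same way together.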